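Swapping the Sulfur Substituent Toward a Pyridinyl Ring

The source may hold more compounds than are shown below. What is called first, only, known or untested is meant among the compounds shown, and "the series" means these compounds.

Of the compounds shown here, three have been measured in a functional assay on HepG2 cells (Homo sapiens) for cytotoxicity, read by MTT assay, with a stated time of 48 h; a higher number here means a weaker inhibitor, a lower number a stronger inhibitor. Compound 1 `CC1=NN(C(=O)CSc2ccccc2)[C@@H](c2cc(Br)cc(Br)c2O)C1` gives 10400 nM in this assay. Compound 2 `O=C(CSCc1ccco1)N1N=C(c2cc3ccccc3oc2=O)C[C@@H]1c1ccc(C(F)(F)F)cc1`, built on a different core, gives 11200 nM in this assay. Compound 3 `CC1=NN(C(=O)CSc2nc3ccccc3s2)[C@@H](c2cc(Br)cc(Br)c2O)C1` gives 8700 nM in this assay, the lowest of the three numbers, although its gaps to compound 1 and to compound 2 both lie within the scatter, so no ranking among the three can be drawn from these numbers.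

Compound 4 `CC1=NN(C(=O)CSc2ccccn2)[C@@H](c2cc(Br)cc(Br)c2O)C1` takes one step on from compound 3: pyridin-2-yl in place of 1,3-benzothiazol-2-yl on a sulfur. Among the compounds with values here, only one measured step bears on this change, the earlier exchange of the group on the same sulfur, whose other neighbour is a saturated chain carbon, and it is the only guide available here.

Because a 1.2-fold lower number from compound 1 to compound 3 (0.08 log units; within the scatter) stayed within the scatter, the further exchange toward pyridin-2-yl in compound 4 is expected to leave the number close to that of compound 3, with a 1.1-fold higher number from compound 3 to compound 4 (0.04 log units; within the scatter) as the expected step, not beyond the scatter in either direction. Compound 4 is therefore estimated at 9500 nM in this assay, with a range from 4500 nM to 20000 nM.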

Compound 4, half-maximal inhibitory concentration: 24700 nM
For compound 4 the middle estimate is 2.6-fold (0.41 log units) below the measured one; measured number outside the range, above it.
By their numbers in this assay, from the lowest: compounds 3, 1 and 2 (each within the scatter of the next); then compound 4.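

The group on the sulfur does matter in this assay, although the exchange of phenyl for 1,3-benzothiazol-2-yl gave no step beyond the scatter. Pyridin-2-yl gives the first such steps at this place, both modest (a 2.8-fold higher number from compound 3 to compound 4 (0.45 log units; beyond the scatter) and a 2.4-fold higher number from compound 1 to compound 4 (0.38 log units; beyond the scatter)), and so compound 4 stands apart from both compound 1 and compound 3. A hetero atom in the ring does not by itself go with the higher number, as compound 3, whose 1,3-benzothiazol-2-yl holds 2 hetero atoms in its five-membered aromatic ring, stays within the scatter of compound 1. No measurement is at hand that accounts for this shift, so the reason for it remains unknown.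

The compounds shown leave open whether the shift depends on where the ring nitrogen sits, which pyridin-3-yl or pyridin-4-yl on the same sulfur would test against compound 4. They also leave open whether a ring with a further nitrogen, such as pyrimidin-2-yl, would move the number further from that of compound 1 or bring it back.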